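The source may report more compounds than this note shows. Statements on the series, on what has been measured and on what is new or still open speak of the compounds shown alone.

Measured so far in an assay for binding affinity to dual specificity mitogen-activated protein kinase kinase 4 (Homo sapiens), read by KINOMEscan, tested at 100 nM; on this read-out higher numbers stand for a weaker effect at the one concentration tested and lower numbers for a stronger effect:
Compound 1, `CCCS(=O)(=O)Nc1ccc(F)c(C(=O)c2n[nH]c3ncc(-c4ccccc4F)cc23)c1F`, gives 2%.
Compound 2, `CCCS(=O)(=O)Nc1ccc(F)c(C(=O)c2n[nH]c3ncc(-c4cc(Cl)cc(Cl)c4)cc23)c1F`, gives 73%.

For the measured compounds named here, compound 2 stands highest of the two numbers in this assay; its only neighbour is compound 1, and the step of a number 71 percentage points higher from compound 1 to compound 2 (beyond the scatter) lies beyond the scatter. Compound 3, `CCCS(=O)(=O)Nc1ccc(F)c(C(=O)c2n[nH]c3ncc(-c4ccc(C)c(C)c4)cc23)c1F`, has not yet been measured. It differs from compound 2 in one place: 3,4-dimethylphenyl in place of 3,5-dichlorophenyl on an aromatic carbon. Going by the values given here, the only measured step that bears on this change is the one at the same aromatic carbon, a number 71 percentage points higher from compound 1 to compound 2 (beyond the scatter), which shows that the group on that carbon can shift the read-out in this assay across most of its span. That step exchanged 2-fluorophenyl for 3,5-dichlorophenyl; neither group is 3,4-dimethylphenyl, so the measured data fix neither the direction nor the size of the new step with confidence. Compound 3 is therefore expected to land between the two measured numbers, with an estimated step of a number 28 percentage points lower from compound 2 to compound 3 (beyond the scatter) in this assay and wide uncertainty around it. The estimate for compound 3 in this assay is 45%, expected to fall within a range from 10% to 85%.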

Compound 3, a percentage reported as activity, at one concentration (the size of the read-out at that concentration, not a potency): 20%
Beside the measured number, compound 3's estimate is 25 percentage points above it; measured number inside the range.
By their numbers in this assay, from the lowest: compound 1; then compound 3; then compound 2.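

In this assay, exchanging 3,5-dichlorophenyl for 3,4-dimethylphenyl on this aromatic carbon gives a number 53 percentage points lower from compound 2 to compound 3 (beyond the scatter), although the two groups match in heavy-atom count and each holds one six-membered aromatic ring of carbon only. The weak read-out of the dichlorophenyl group therefore does not extend to every disubstituted phenyl at this position, yet 2-fluorophenyl keeps a lead, with a number 18 percentage points higher from compound 1 to compound 3 (beyond the scatter), a modest step set against the large one from the dichlorophenyl group. Nothing in the data given here accounts for these differences.

The change from compound 2 to compound 3 alters both the substituent atoms and their arrangement on the phenyl ring, so the compounds shown leave open which of the two carries the shift, a question that a 3,4-dichlorophenyl or a 3,5-dimethylphenyl group at this position would help to separate. From the compounds shown here alone, it also remains open how this position would respond to a phenyl ring bearing an amine or a carboxylic acid, or to a pyridine ring in place of the phenyl ring.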